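Aryl group exchange on the pyrazole nitrogen of the core

A few compounds are considered here, and "the series" means these few. Any claim that something is new, unique, unknown or untested is made for them only; others in the source may bear on it.

Compound 1 `Cc1nn(-c2ccccc2C(C)C)c2c1[C@@H](c1ccc(Oc3ccccc3)cc1)S[C@@H](C)C(=O)N2` is the reference point here. Among the measured compounds shown here, in an assay on isolated protein for agonist activity at Bile acid receptor (Homo sapiens), read by AlphaScreen, with a stated time of 30 min (on this read-out higher numbers stand for an effect only at larger amounts of compound and lower numbers for an effect already at smaller amounts), compound 1 gives 1900 nM, the lower of the two numbers measured so far. For the measured compounds named here, compound 2 `Cc1nn(-c2ccccc2C(F)(F)F)c2c1C(c1ccc(Oc3ccccc3)cc1)SC(C)C(=O)N2` is its only neighbour; in this assay compound 2 gives 2000 nM, and the two values lie within the scatter of each other, so nothing separates them on this read-out. Going by the values given here, no single-point step between measured compounds exists in the set.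

Compound 3 `Cc1cccc(-n2nc(C)c3c2NC(=O)[C@H](C)S[C@@H]3c2ccc(Oc3ccccc3)cc2)c1` carries the change 3-methylphenyl in place of 2-isopropylphenyl on an aromatic nitrogen on the shared core. Among the compounds with values here, with only two measured values, both close together, there is no basis for a large expected shift in either direction; the step of a 1.6-fold higher number from compound 1 to compound 3 (0.20 log units; within the scatter) is therefore expected to stay within or only slightly beyond the scatter, leaning weaker. Compound 3 is estimated at 3000 nM, with a plausible range of 1000 nM to 9000 nM.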

Compound 3, half-maximal effective concentration: 2400 nM
Compound 3: the middle estimate sits 1.3-fold (0.10 log units) above what was measured; the range from low to high includes it.
By their numbers in this assay, from the lowest: compounds 1, 2 and 3 (each within the scatter of the next).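

In this assay, among the compounds shown here, 3-methylphenyl in place of 2-isopropylphenyl on the aromatic nitrogen gives a 1.3-fold higher number from compound 1 to compound 3 (0.10 log units; within the scatter) and is the first single-place comparison at this position. The position therefore accepts an aryl group of 7 heavy atoms as well as one of 9 heavy atoms, with a different substituent on the phenyl ring, and the read-out does not separate the two. No measurement on hand bears on the reason for this.

Still open, as far as these compounds go, is whether a phenyl ring carrying an amine or a carboxylic acid, or a longer alkyl chain in place of the aryl group, would move the number beyond the scatter. The values shown also lie too close together to rank the aryl groups at this position.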